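Carbamate to Alkylamine on the Piperidine Nitrogen

The compounds below may be only part of what the source reports. "The series", "measured", "known", "first", "only" and "open" are said of these compounds alone.

Compound 1, `CC(C)(C)OC(=O)N1CCC(O[C@H]2CC[C@H](Oc3cnc(S(C)(=O)=O)cn3)CC2)CC1`: 64 nM in a functional assay on isolated protein for agonist activity at Glucose-dependent insulinotropic receptor (Rattus norvegicus), read by HTRF and cAMP accumulation; on this read-out higher numbers stand for an effect only at larger amounts of compound and lower numbers for an effect already at smaller amounts
Compound 2, `CC(C)OC(=O)N1CCC(O[C@H]2CC[C@H](Oc3cnc(S(C)(=O)=O)cn3)CC2)CC1`: 119 nM
Compound 3, `CS(=O)(=O)c1cnc(O[C@H]2CC[C@H](OC3CCN(C(=O)Oc4ccccc4)CC3)CC2)cn1`: 71.8 nM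

Compound 3 stands second highest of the three numbers in this assay; against compound 1 it differs by a 1.1-fold higher number from compound 1 to compound 3 (0.05 log units; within the scatter) and against compound 2 by a 1.7-fold lower number from compound 2 to compound 3 (0.22 log units; within the scatter), so all three sit within the scatter of one another. Compound 4, `CS(=O)(=O)c1cnc(O[C@H]2CC[C@H](OC3CCN(CC4(C(F)(F)F)CCC4)CC3)CC2)cn1`, carries (1-(trifluoromethyl)cyclobutyl)methyl in place of phenoxycarbonyl on an amine nitrogen in a ring. The measured steps, a 1.9-fold higher number from compound 1 to compound 2 (0.27 log units; within the scatter) and the two above, all exchanged one ester group of the carbamate for another and stayed within the scatter; none removes the carbamate itself, so they do not bear directly on this change. Because of a 1.1-fold higher number from compound 1 to compound 3 (0.05 log units; within the scatter) the position tolerates variation, yet the new group is of a different kind, and a larger spread is expected. Compound 4 is estimated at 100 nM, between 20 nM and 600 nM, which means an expected step of a 1.4-fold higher number from compound 3 to compound 4 (0.14 log units; within the scatter).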

Compound 4, half-maximal effective concentration: 80 nM
Compound 4: middle estimate off by 1.3-fold (0.10 log units), on the high side; the range from low to high includes it.
By their numbers in this assay, from the lowest: compounds 1, 3, 4 and 2 (each within the scatter of the next).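

In this assay the carbamate proves dispensable on the amine nitrogen in a ring: the step is a 1.1-fold higher number from compound 3 to compound 4 (0.05 log units; within the scatter) when (1-(trifluoromethyl)cyclobutyl)methyl, which has no carbonyl, takes the place of phenoxycarbonyl. The steps of a 1.5-fold lower number from compound 2 to compound 4 (0.17 log units; within the scatter) and a 1.3-fold higher number from compound 1 to compound 4 (0.10 log units; within the scatter) likewise replace a carbamate with this group and remain within the scatter. No evidence here accounts for this tolerance. The compounds shown leave open whether an amide, a benzyl group or a plain methyl on this nitrogen would also stay within the scatter, and whether the trifluoromethyl or the cyclobutyl part of the new group matters.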